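A few compounds are considered here, and "the series" means these few. Any claim that something is new, unique, unknown or untested is made for them only; others in the source may bear on it.

Measured in a functional assay on HOS-TE85 cells (Homo sapiens) for inhibition, read by CCK-8 assay, with a stated time of 72 h; a higher number here means a weaker inhibitor, a lower number a stronger inhibitor:
Compound 1 `COc1ccc(C)cc1N1C(=O)CSC1c1cccc(C(=O)NCCCCc2ccccc2)c1`: 300 nM
Compound 2 `CCN1C(=O)CSC1c1cccc(C(=O)NCCCCc2ccccc2)c1`: > 1000 nM (a limit)
Compound 3 `O=C(NCCCCc1ccccc1)c1cccc(C2SCC(=O)N2c2ccc(-c3ccccc3)cc2)c1`: > 1000 nM (a limit)

Compound 3 has only a limit and no number, and it shares (the limit of > 1000 nM in this assay, at which 2 of the 3 values shown sit). The next case is compound 4 `O=C(NCCCCc1ccccc1)c1cccc(C2SCC(=O)N2c2ccccc2F)c1`, with 2-fluorophenyl in place of 4-phenylphenyl on an amide-type nitrogen in a ring.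

Two measured steps at this same place bear on it. These are an at least 3.3-fold higher number from compound 1 to compound 3 (0.52 log units; beyond the scatter) and an at least 3.3-fold higher number from compound 1 to compound 2 (0.52 log units; beyond the scatter), both beyond the scatter. Of the three compounds, only compound 1 gives a number, 300 nM, and it carries one substituted phenyl ring, as compound 4 does. That single resemblance is thin support, and a further limit remains quite possible. In this assay the expected change is a modest move to a lower number, estimated as an at least 1.4-fold lower number from compound 3 to compound 4 (0.15 log units; that floor lies within the scatter). The estimate for compound 4 is 700 nM, with an expected range of 250 nM to 2000 nM.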

Compound 4, half-maximal inhibitory concentration: 34.1 nM
Compound 4: the middle estimate sits 21-fold (1.31 log units) above what was measured; the measured number lies below the stated range.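

In this assay, among the compounds shown here, this position turns out to allow much stronger inhibition than the earlier compounds showed: 2-fluorophenyl gives an at least 29-fold lower number from compound 3 to compound 4 (1.46 log units; beyond the scatter), and an at least 29-fold lower number from compound 2 to compound 4 (1.46 log units; beyond the scatter). The comparison with numbers at both ends gives an 8.8-fold lower number from compound 1 to compound 4 (0.94 log units; beyond the scatter), so carrying one substituted phenyl ring does not by itself set the level; what sits on that ring matters. Compound 2 and compound 3 each give a limit and not a number, so the two steps from them are floors, and the step between them cannot be read: the limit of > 1000 nM in this assay, at which 2 of the 4 values shown sit.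

From the compounds shown here alone, how much of the gain belongs to the fluorine stays open; an unsubstituted phenyl, or chlorine in place of fluorine, would bear on that. Also open, going by these compounds, is whether the gain holds with a shorter chain on the amide.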